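The compounds below may be only part of what the source reports. "The series", "measured", "known", "first", "only" and "open" are said of these compounds alone.

Compound 1 `O=S(=O)(NCCNC(=S)Nc1cc(C(F)(F)F)cc(C(F)(F)F)c1)c1ccc(-c2ccccc2OCc2cccc(O)c2)s1` and compound 2 `O=C(NCCNS(=O)(=O)c1ccc(-c2ccccc2OCc2cccc(O)c2)s1)Nc1cc(C(F)(F)F)cc(C(F)(F)F)c1` share most of their structure, but the difference between their two cores is not broken down here. In a functional assay on RS4-11 cells (Homo sapiens) for inhibition, read by CCK-8 assay, with a stated time of 48 h (a higher number here means a weaker inhibitor, a lower number a stronger inhibitor), compound 1 gives 12000 nM, while compound 2 gives 3000 nM. Compound 3 `O=S(=O)(NCCNC(=S)Nc1cc(C(F)(F)F)cc(C(F)(F)F)c1)c1ccc(-c2ccccc2O[C@H]2CC[C@@H](O)CC2)s1` arises from compound 1 by a single change, (4-hydroxycyclohexyl in place of 3-hydroxybenzyl on an oxygen on an aromatic ring), and in this assay compound 3 gives 6300 nM, which amounts to a step of a 1.9-fold lower number from compound 1 to compound 3 (0.28 log units; within the scatter). Compound 4 `O=C(NCCNS(=O)(=O)c1ccc(-c2ccccc2O[C@H]2CC[C@@H](O)CC2)s1)Nc1cc(C(F)(F)F)cc(C(F)(F)F)c1` carries the same change, now made on compound 2, (4-hydroxycyclohexyl in place of 3-hydroxybenzyl on an oxygen on an aromatic ring). Because the earlier step was a 1.9-fold lower number from compound 1 to compound 3 (0.28 log units; within the scatter), a step of similar size is expected here, a 1.5-fold lower number from compound 2 to compound 4 (0.18 log units; within the scatter). On that basis compound 4 is estimated to give about 2000 nM in this assay, most likely somewhere between 900 nM and 5000 nM.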

Compound 4, half-maximal inhibitory concentration: 9300 nM
The estimate for compound 4 lay 4.7-fold (0.67 log units) below the measured number; the measured number lies above the stated range.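

On the core of compound 2, putting 4-hydroxycyclohexyl in place of 3-hydroxybenzyl on the oxygen gives a 3.1-fold higher number from compound 2 to compound 4 (0.49 log units; beyond the scatter) in this assay. The effect of this change therefore did not carry over from one core to the other, so the step seen on one core is a poor guide to the step on the other: the same change on two cores in this assay, a 1.9-fold lower number (0.28 log units; within the scatter) from compound 1 to compound 3 and a 3.1-fold higher number (0.49 log units; beyond the scatter) from compound 2 to compound 4, 5.9-fold (0.77 log units) apart, beyond the scatter of two such steps

These four compounds show that the two cores respond differently, but not why they do, and two pairs give no rule for any further core. Going by these compounds, it remains open how other groups on that oxygen would behave on these two cores, such as a plain methyl or a cyclohexyl ring carrying an amine instead of the hydroxyl. On these data alone, the effect of the other arrangement of the two stereocentres in 4-hydroxycyclohexyl also remains open.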